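This account rests on a few compounds, and the source may have more. Where it says the series, first, only, none or still open, it means among the compounds named here.

Compound 1 `Cc1ccc(-c2cc3ncn([C@H]4CCN(C(=O)N(C)[C@H]5CCN(C)C5)C4)c(=O)c3s2)c(C)c1` gives 49 nM in an assay on isolated protein for binding affinity to melanin-concentrating hormone receptor 1 (Homo sapiens); on this read-out lower numbers stand for stronger inhibition and higher numbers for weaker inhibition.
Compound 2 `CN1CC[C@H](N(C)C(=O)N2CC[C@H](n3cnc4cc(-c5ccc(OC(F)(F)F)cc5)sc4c3=O)C2)C1` gives 39 nM in this assay.
Compound 3 `Cc1ccc(-c2cc3ncn([C@H]4CCN(C(=O)N(C)[C@H]5CCN(C6CCOCC6)C5)C4)c(=O)c3s2)c(C)c1` gives 70 nM in this assay.

Among these three, compound 3 carries the highest number, but its distance to compound 1 and to compound 2 stays within the usual scatter of repeated measurements, so no real order among them can be claimed. The unmeasured compound 4 `CN(C(=O)N1CC[C@H](n2cnc3cc(-c4ccc5c(c4)OCCO5)sc3c2=O)C1)[C@H]1CCN(C2CCOCC2)C1` keeps the shared core and the amine part of compound 3 and changes only the aromatic group attached to the five-membered ring: 2,3-dihydro-1,4-benzodioxin-6-yl in place of 2,4-dimethylphenyl on an aromatic carbon.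

Within the data shown here, one measured step touches the same position. Going a 1.3-fold lower number from compound 1 to compound 2 (0.10 log units; within the scatter) swapped the same 2,4-dimethylphenyl for another aromatic group, and the number barely moved. The other step, a 1.4-fold higher number from compound 1 to compound 3 (0.15 log units; within the scatter), changed the amine instead and does not bear directly on this exchange. Among the measured compounds shown here, with only one comparable example, and that one flat, the expectation is a step for compound 4 of a 1.1-fold higher number from compound 3 to compound 4 (0.06 log units; within the scatter) in this assay, which is no step beyond the scatter. Compound 4 is therefore estimated at 80 nM in this assay, within a range from 35 nM to 180 nM.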

Compound 4, inhibition constant: 45 nM
Estimate against measurement, compound 4: 1.8-fold (0.25 log units) above, within the range that was stated.
By their numbers in this assay, from the lowest: compounds 2, 4, 1 and 3 (each within the scatter of the next).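

In this assay, putting 2,3-dihydro-1,4-benzodioxin-6-yl in place of 2,4-dimethylphenyl on the aromatic carbon next to the ring sulfur gives a 1.6-fold lower number from compound 3 to compound 4 (0.19 log units; within the scatter), so this position carries a group with 10 heavy atoms instead of 8, an added non-aromatic six-membered ring and 2 hydrogen-bond acceptors instead of 0 without a step beyond the scatter. The earlier exchange at this position, a 1.3-fold lower number from compound 1 to compound 2 (0.10 log units; within the scatter), had methyl on the ring amine nitrogen, whereas this one has oxan-4-yl there, so among the compounds shown a flat result at this position holds with both amine groups. Nothing available explains why the number stays so flat across these exchanges.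

Every group shown at this position is built on a benzene ring, so it remains open whether a saturated ring such as cyclohexyl, or a phenyl ring bearing a carboxylic acid or a primary amine, would also stay within the scatter. Also open, as far as these compounds go, is how 2,3-dihydro-1,4-benzodioxin-6-yl behaves with methyl rather than oxan-4-yl on the ring amine nitrogen.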